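Swapping a Pyridine Ring for a Methylphenyl Ring

This account rests on a few compounds, and the source may have more. Where it says the series, first, only, none or still open, it means among the compounds named here.

Of the compounds shown here, two with a shared core have been measured. Compound 1 `COc1ccc(C(=O)NCc2ccc(CNS(=O)(=O)c3ccc(C)cc3)cc2)cc1` gives 100 nM in an assay on MDA-MB-231 cells for binding affinity to C-X-C chemokine receptor type 4 (Homo sapiens), read by immunofluorescence and microscopy, with stated times of 10 min and 30 min; a lower number here means that less compound is needed, a higher number that more compound is needed for the effect. Going by the values given here, compound 2 `Cc1ccc(S(=O)(=O)NCc2ccc(CNC(=O)c3ccncc3)cc2)cc1` gives 10 nM in this assay, the lowest of the two numbers so far; the single step, a 10-fold lower number from compound 1 to compound 2 (1.00 log units; beyond the scatter), came from pyridin-4-yl in place of 4-methoxyphenyl on a carbonyl carbon. Compound 3 `Cc1ccc(S(=O)(=O)NCc2ccc(CNC(=O)c3cccc(C)c3)cc2)cc1` differs from compound 2 by 3-methylphenyl in place of pyridin-4-yl on a carbonyl carbon. Among the compounds with values here, the only step that bears on this change is a 10-fold lower number from compound 1 to compound 2 (1.00 log units; beyond the scatter), which moved to a lower number when pyridin-4-yl replaced a ring of carbon only; the present change goes the other way, giving up pyridin-4-yl for a ring of carbon only. A rise in the number is therefore expected, a 6.0-fold higher number from compound 2 to compound 3 (0.78 log units; beyond the scatter), though 3-methylphenyl is not 4-methoxyphenyl, so a somewhat smaller step is plausible. Compound 3 is estimated at 60 nM, within 15 nM to 300 nM.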

Compound 3, effective concentration (reported as EC, without a stated level of effect): 1000 nM
The estimate for compound 3 lay 17-fold (1.22 log units) below the measured number; the whole stated range lies below it.
By their numbers in this assay, from the lowest: compound 2; then compound 1; then compound 3.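

In this assay, 3-methylphenyl in place of pyridin-4-yl on a carbonyl carbon gives a 100-fold higher number from compound 2 to compound 3 (2.00 log units; beyond the scatter) and so shows that this position can move the number much further than the first step suggested. The two rings of carbon only are not equivalent either: 3-methylphenyl in place of 4-methoxyphenyl gives a 10-fold higher number from compound 1 to compound 3 (1.00 log units; beyond the scatter) in the same assay, so the loss of the ring nitrogen is not the only thing that matters here. No measurement at hand offers an explanation for these differences.

Pyridin-4-yl has so far been compared only with rings that carry a methyl or methoxy group, so the ring nitrogen and those added groups cannot be told apart. Plain phenyl and pyridin-3-yl would help to separate them, and it remains open how this position responds to a ring bearing an amine.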